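The compounds below may be only part of what the source reports. "The series", "measured", "known", "first", "only" and "open" are said of these compounds alone.

Three compounds have been measured in a functional assay on RAW264.7 cells (Mus musculus) for inhibition, with a stated time of 30 min; a higher number here means a weaker inhibitor, a lower number a stronger inhibitor:

compound 1, `C=C1C(=O)OC[C@@H]1CCOC(=O)Nc1ccc(C(C)C)cc1`: 1580 nM
compound 2, `C=C1C(=O)OC[C@@H]1CCOC(=O)Nc1ccc(Br)cc1`: 720 nM
compound 3, `C=C1C(=O)OC[C@@H]1CCOC(=O)Nc1ccc(CCCC)cc1`: 1230 nM

All three share one core and differ only in the group on an aromatic carbon. Compound 3 gives the second highest of the three numbers; its nearest neighbour is compound 1, as a 1.3-fold lower number from compound 1 to compound 3 (0.11 log units; within the scatter) shows, and the remaining step is a 1.7-fold higher number from compound 2 to compound 3 (0.23 log units; within the scatter). Among the measured compounds shown here, the only change here that reached beyond the scatter is a 2.2-fold lower number from compound 1 to compound 2 (0.34 log units; beyond the scatter).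

Compound 4, `C=C1C(=O)OC[C@@H]1CCOC(=O)Nc1ccc(OC)cc1`, is the next step from compound 3: methoxy in place of butyl on an aromatic carbon. For the measured compounds named here, no measured compound carries a methoxy, so the three steps above are the only guide, and they bear on it only in a general way: swapping one group on this aromatic carbon for another has moved the number modestly at most. The expectation for this assay is therefore a step about as small as a 1.0-fold lower number from compound 3 to compound 4 (0.01 log units; within the scatter), with no direction beyond the scatter claimed. Compound 4 is estimated at 1200 nM, expected to fall between 500 nM and 2800 nM.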

Compound 4, half-maximal inhibitory concentration: 1090 nM
Compound 4: middle estimate off by 1.1-fold (0.04 log units), on the high side, and the stated range covers the measured number.
By their numbers in this assay, from the lowest: compounds 2, 4, 3 and 1 (each within the scatter of the next, the first and the last beyond it).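

In this assay, methoxy is a shorter group than butyl, with 2 heavy atoms against 4, and it brings a hydrogen-bond acceptor, yet a 1.1-fold lower number from compound 3 to compound 4 (0.05 log units; within the scatter) shows that this exchange barely shifts the number. Methoxy also stays close to the other two groups, with a 1.5-fold higher number from compound 2 to compound 4 (0.18 log units; within the scatter) and a 1.4-fold lower number from compound 1 to compound 4 (0.16 log units; within the scatter) as its steps. Among the compounds shown here, on this aromatic carbon, para to a large group, an oxygen-linked group therefore fits into the same narrow band as the bromo and the two carbon chains, and no step to or from methoxy passes the scatter.

Nothing measured here explains why these exchanges change the number so little. As far as these compounds go, whether an amine, a carboxylic acid or a much longer chain at this position would move the number further remains open.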